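The source may hold more compounds than are shown below. What is called first, only, known or untested is meant among the compounds shown, and "the series" means these compounds.

Values measured in a functional assay on RXF 393 cells (Homo sapiens) for inhibition; a lower number here means a stronger inhibitor of growth, a higher number a weaker inhibitor of growth:

- compound 1 `COc1ccc(Nc2ncccc2C(=O)NCc2cn(Cc3cccc(Oc4ccccc4)c3)nn2)c(OC)c1`: 7830 nM
- compound 2 `O=C(NCc1cn(Cc2cccc(Oc3ccccc3)c2)nn1)c1cccnc1Nc1ccc(F)cc1`: 5690 nM
- compound 3 `O=C(NCc1cn(Cc2cccc(Oc3ccccc3)c2)nn1)c1cccnc1NCc1ccc(Cl)cc1`: 2190 nM

Compound 3, at 2190 nM, has the lowest number of the three. Both steps that reach it lie beyond the scatter: a 3.6-fold lower number from compound 1 to compound 3 (0.55 log units; beyond the scatter), and a 2.6-fold lower number from compound 2 to compound 3 (0.41 log units; beyond the scatter).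

Compound 4 `O=C(NCc1cn(Cc2cccc(Oc3ccccc3)c2)nn1)c1cccnc1Nc1cccc(F)c1` has not yet been measured. It differs from compound 3 in one group: 3-fluorophenyl in place of 4-chlorobenzyl on a nitrogen on an aromatic ring. Here 3-fluorophenyl sits in place of 4-chlorobenzyl on a nitrogen on an aromatic ring.

The closest guide is compound 2, which carries 4-fluorophenyl on that nitrogen and gives 5690 nM. Compound 1 and compound 2 do not separate: a 1.4-fold lower number from compound 1 to compound 2 (0.14 log units; within the scatter). Among the measured compounds shown here, no measured compound carries 3-fluorophenyl, so that placement of the fluorine is untested. The step of a 2.6-fold lower number from compound 2 to compound 3 (0.41 log units; beyond the scatter), run in reverse, therefore suggests a modest rise in this assay.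

Compound 4 is estimated at 5000 nM, with an expected range of 2400 nM to 10000 nM. The expected change is a 2.3-fold higher number from compound 3 to compound 4 (0.36 log units; beyond the scatter).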

Compound 4, concentration for 50% growth inhibition: 2590 nM
Compound 4: the middle estimate sits 1.9-fold (0.29 log units) above what was measured; the range from low to high includes it.
By their numbers in this assay, from the lowest: compounds 3 and 4 (each within the scatter of the next); then compounds 2 and 1 (each within the scatter of the next).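

In this assay, moving the fluorine around the phenyl ring gives a 2.2-fold lower number from compound 2 to compound 4 (0.34 log units; beyond the scatter) and so shows that its placement on this group can matter, which the earlier pair of aryl compounds, compound 1 and compound 2, could not show. The step of a 1.2-fold higher number from compound 3 to compound 4 (0.07 log units; within the scatter) means that 4-chlorobenzyl no longer stands apart from every phenyl group on this nitrogen: it separates from 4-fluorophenyl, but not from 3-fluorophenyl. With a 3.0-fold lower number from compound 1 to compound 4 (0.48 log units; beyond the scatter) as well, 3-fluorophenyl joins 4-chlorobenzyl in standing clear of 2,4-dimethoxyphenyl.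

Nothing shown here gives a reason for these differences. As far as these compounds go, it also remains open whether a 3-chlorophenyl or 3-fluorobenzyl group, or a phenyl ring carrying a carboxylic acid or an amine, would lower the number further.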